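The source may hold more compounds than are shown below. What is called first, only, known or untested is meant among the compounds shown, and "the series" means these compounds.

Compound 1 `O=C(Nc1cccc(S(=O)(=O)Nc2ccccc2)c1)c1ccc(Cl)cc1Cl`, in a functional assay on HEK293 cells for agonist activity at probable G-protein coupled receptor 27 (Homo sapiens), read by a luciferase reporter and beta-arrestin recruitment, with a stated time of 10 min (a lower number here means that less compound is needed, a higher number that more compound is needed for the effect), a limit only: > 100000 nM.
Compound 2 `CN(c1ccccc1)S(=O)(=O)c1ccc(NC(=O)c2ccc(Cl)cc2Cl)cc1`, in this assay 2570 nM.
Compound 3 `O=C(Nc1ccc(S(=O)(=O)Nc2ccccc2)cc1)c1ccc(Cl)cc1Br`, in this assay 1020 nM.

Of the two numbers in hand, compound 3 holds the lowest. Compound 2 gives the nearest number, and its gap to compound 3 lies beyond the usual scatter, so compound 3 can be called the more potent of the two. For compound 1 this assay reports no number but (the limit of > 100000 nM in this assay, at which 1 of the 3 values shown sits), and no more can be said of it than that it is a limit.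

The step to be followed leads from compound 3 to compound 4 `O=C(Nc1ccc(S(=O)(=O)Nc2ccccc2)cc1)c1ccc(I)cc1F`. The two structures differ in one place: 2-fluoro-4-iodophenyl in place of 2-bromo-4-chlorophenyl on a carbonyl carbon. The shared core of the two compounds, with its amide and its sulfonamide, stays the same. Within the data shown here, no pair of the measured compounds differs in this place alone, so there is no measured step to lean on. One would therefore expect a step from compound 3 to compound 4 of about a 1.6-fold higher number from compound 3 to compound 4 (0.20 log units; within the scatter), a modest rise that may not clear the scatter. For compound 4 the expected value in this assay is 1600 nM, with a likely range from 500 nM to 5000 nM.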

Compound 4, half-maximal effective concentration: 5130 nM
Compound 4: the middle estimate sits 3.2-fold (0.51 log units) below what was measured, and the stated range ends below it.
By their numbers in this assay, from the lowest: compound 3; then compounds 2 and 4 (each within the scatter of the next). At a limit, above all of these: compound 1.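

In this assay, among these compounds, 2-fluoro-4-iodophenyl in place of 2-bromo-4-chlorophenyl on a carbonyl carbon gives a 5.0-fold higher number from compound 3 to compound 4 (0.70 log units; beyond the scatter), the first measured step at this place, and it shows that the number responds to a change in this group alone. The response appears although the two groups match in everything counted for them: each has the same number of heavy atoms and a six-membered aromatic ring of carbon only, and neither has hydrogen-bond donors, hydrogen-bond acceptors or a net charge, so the step follows the identity of the halogens and not any of these counts. Nothing measured here explains why the number rises at this change.

Both halogens change in this single step, so the compounds shown do not separate what the fluorine, the iodine, the loss of the bromine and the loss of the chlorine each contribute. Also open, from the compounds shown here alone, is how the number would respond if this phenyl group carried something other than halogens, such as a methoxy group, an amine or a carboxylic acid.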